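Removing the tert-butoxy group from the aryl ring

This account rests on a few compounds, and the source may have more. Where it says the series, first, only, none or still open, it means among the compounds named here.

Measured compounds:
compound 1 `Oc1cccc(/C=C2\CCCN=C2c2cccnc2)c1` 1170 nM
compound 2 `CC(C)(C)C(=O)Oc1ccc(/C=C2\CCCN=C2c2cccnc2)cc1` 830 nM
compound 3 `CC(C)(C)Oc1ccc(/C=C2\CCCN=C2c2cccnc2)cc1` 2170 nM

In an assay on membranes from brain for displacement of a labelled ligand from Neuronal acetylcholine receptor; alpha4/beta2 (Rattus norvegicus), with a stated time of 3 h (a lower number here means a stronger inhibitor, a higher number a weaker inhibitor), compound 3 gives the highest number of the three. Its nearest neighbour is compound 1, whose value lies within the scatter of that of compound 3, while the step from compound 2 to compound 3 is beyond the scatter: a 2.6-fold higher number from compound 2 to compound 3 (0.42 log units; beyond the scatter), from the exchange of tert-butyl for (tert-butyl)carbonyl on the oxygen.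

Compound 4 `C(=C1\CCCN=C1c1cccnc1)\c1ccccc1` has not yet been measured. It differs from compound 3 in one place: hydrogen in place of tert-butoxy on an aromatic carbon. For the measured compounds named here, no measured step removes a whole substituent from this ring, so the only guide is that all three measured values sit within a modest span of each other, and the one step that is beyond the scatter, from compound 2 to compound 3, is itself small. Compound 4 is therefore expected to fall in the same region, with a step of a 1.7-fold lower number from compound 3 to compound 4 (0.22 log units; within the scatter) that may well lie within the scatter. The estimate for compound 4 is 1300 nM, between 400 nM and 4000 nM.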

Compound 4, inhibition constant: 850 nM
Compound 4: middle estimate off by 1.5-fold (0.18 log units), on the high side; the range from low to high includes it.
By their numbers in this assay, from the lowest: compounds 2, 4, 1 and 3 (each within the scatter of the next, the first and the last beyond it).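

In this assay, for the compounds shown here, the ring needs no substituent at this place to keep its binding in the range of the series, and the removal of tert-butoxy gives a 2.6-fold lower number from compound 3 to compound 4 (0.41 log units; beyond the scatter) as the first measured step that takes a whole group off the ring. Hydrogen is not separated from the two other substituents, with a 1.0-fold higher number from compound 2 to compound 4 (0.01 log units; within the scatter) for ((tert-butyl)carbonyl)oxy and a 1.4-fold lower number from compound 1 to compound 4 (0.14 log units; within the scatter) for hydroxy, so among these compounds only tert-butoxy stands apart from the bare ring. Nothing available explains why tert-butoxy alone stands apart.

As far as these compounds go, it remains open whether a smaller ether such as methoxy would read like tert-butoxy or like hydrogen. Whether an amine or a carboxylic acid at this place would leave the value in this range is also unknown.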